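The source may report more compounds than this note shows. Statements on the series, on what has been measured and on what is new or still open speak of the compounds shown alone.

Measured so far:
- compound 1 `c1ccc(C(/N=C2\CCCCCN2)C2CCC2)cc1`: 44%
- compound 2 `c1csc(C/N=C2\CCCCCN2)c1`: 19%
- compound 3 `c1ccc(C(/N=C2\CCCCCN2)c2ccco2)cc1`: 52%

These numbers come from a functional assay on the whole organism (plasma, strain Sprague-Dawley) with Rattus norvegicus as the target, with a stated time of 2 h, at a dose of 100 mg/kg by the oral route; on this read-out lower numbers stand for a weaker effect and higher numbers for a stronger effect at the one dose given. Compound 3 carries the largest of the three values, but the step of a number 8 percentage points higher from compound 1 to compound 3 (within the scatter) is within the scatter, so compound 1 and compound 3 cannot be told apart on this read-out. Among the measured compounds shown here, compound 2 lies well below them, and its gap to compound 3 is beyond the scatter; compound 2 lacks the phenyl group of the other two, and no single-change step links it to them.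

Compound 4 `c1ccc(C(/N=C2\CCCCCN2)c2cccs2)cc1` differs from compound 3 by one change: thiophen-2-yl in place of furan-2-yl on a saturated chain carbon bound to an aromatic carbon and a double-bonded nitrogen. For the measured compounds named here, the only measured step at this same position is a number 8 percentage points higher from compound 1 to compound 3 (within the scatter), which swapped a different group into this place and stayed within the scatter. Going by the values given here, no measured step exchanges furan-2-yl for thiophen-2-yl directly, so the expectation rests on the small size of the one related step. No change beyond the scatter is expected, and the step of a number 2 percentage points lower from compound 3 to compound 4 (within the scatter) is estimated accordingly. In this assay compound 4 is therefore expected to give about 50%, in the range 30% to 70%.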

Compound 4, a percentage reported as inhibition, in the whole organism at one dose (the size of the read-out at that dose, not a potency): 50%
Compound 4: the middle estimate sits on the measured number at the digits printed; measured number inside the range.
By their numbers in this assay, from the lowest: compound 2; then compounds 1, 4 and 3 (each within the scatter of the next).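

In this assay, compound 4 adds a direct exchange of one five-membered aromatic ring for another at this position: thiophen-2-yl in place of furan-2-yl gives a number 2 percentage points lower from compound 3 to compound 4 (within the scatter), and thiophen-2-yl in place of cyclobutyl gives a number 6 percentage points higher from compound 1 to compound 4 (within the scatter), so these three groups cannot be told apart on this read-out. Among the compounds shown here, compound 4 also provides the first single change beyond the scatter, phenyl in place of hydrogen on the same carbon, which gives a number 31 percentage points higher from compound 2 to compound 4 (beyond the scatter), so in these compounds the difference lies with the phenyl group and not with the choice among the other three groups. Nothing given here explains either result.

On these data alone, it remains open how an amine, a carboxylic acid or a longer chain on this carbon would compare. Replacing the phenyl group itself with any other group also remains untested among the compounds shown.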